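The source may report more compounds than this note shows. Statements on the series, on what has been measured and on what is new or still open speak of the compounds shown alone.

Measured so far:
compound 1, `CCCCN(C(=O)c1ccc(C(F)(F)F)cc1)c1nnc(-c2ccc(S(=O)(=O)NCCC(=O)O)cc2)s1`: 13.8 uL/min
compound 2, `CCCCN(C(=O)c1ccc(C(F)(F)F)cc1)c1nnc(-c2cccc3[nH]ccc23)s1`: 77.2 uL/min

In an ADME assay on microsomes from liver (Homo sapiens) for metabolic stability, read by LC-MS, tested at 0.5 uM (on this read-out higher numbers stand for fast clearance and lower numbers for slow clearance), compound 2 stands highest of the two numbers. Its nearest neighbour, compound 1, gives 13.8 uL/min, a lower number by a gap that lies beyond the usual scatter of repeated measurements, so the two compounds are clearly separated on this read-out.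

Compound 3, `CCCCN(C(=O)c1ccc(C(F)(F)F)cc1)c1nnc(-c2ccc(F)c3[nH]ccc23)s1`, is the next compound to be measured. It differs from compound 2 in one place: fluoro in place of hydrogen on an aromatic carbon. The two compounds share everything else, including the butyl chain on the amide nitrogen and the trifluoromethyl-bearing aromatic ring of the amide.

Going by the values given here, since no single-change step between measured compounds is available in this assay, the expectation for compound 3 rests on the change itself and on compound 2 alone. A small step, if any, toward slower clearance is expected, a 1.3-fold lower number from compound 2 to compound 3 (0.11 log units; within the scatter), well within the scatter. For compound 3 the estimated value in this assay is 60 uL/min, with a range from 30 uL/min to 120 uL/min.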

Compound 3, intrinsic clearance in a liver preparation (reported as CLH), per the amount of preparation that the assay uses: 48.6 uL/min
For compound 3 the middle estimate is 1.2-fold (0.09 log units) above the measured one, within the range that was stated.
By their numbers in this assay, from the lowest: compound 1; then compounds 3 and 2 (each within the scatter of the next).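

In this assay, fluoro in place of hydrogen on this aromatic carbon, para to a large group, comes with a 1.6-fold lower number from compound 2 to compound 3 (0.20 log units; within the scatter). Going by these compounds alone, this is the first single-change step among the compounds, and it shows that at this position the change does not separate compound 3 from compound 2 on this read-out. Nothing measured here speaks to what lies behind this result.

On these data alone, whether a different group at the same position, such as chloro, methoxy or an amine, would give a step beyond the scatter remains open, as does the outcome of fluoro on another carbon of the same ring. The compounds shown also leave open how a longer chain in place of the butyl chain on the amide nitrogen would read in this assay.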